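Bromo in Place of Methoxy on the Pendant Aryl Ring

The source may report more compounds than this note shows. Statements on the series, on what has been measured and on what is new or still open speak of the compounds shown alone.

Compound 1 `COc1ccccc1N1CCN(CCCOc2ccc(C(=O)Nc3ccccc3OCCCC(=O)O)cc2)CC1`: 41000 nM
Compound 2 `COc1ccccc1N1CCN(CCC(Oc2ccc(C(=O)Nc3ccccc3OCCCC(=O)O)cc2)c2ccc(C)cc2)CC1`: 67 nM
Compound 3 `COc1ccc(C(CCN2CCN(c3ccccc3OC)CC2)Oc2ccc(C(=O)Nc3ccccc3OCCCC(=O)O)cc2)cc1`: 170 nM

In an assay on isolated protein for inhibition of steroid 5-alpha-reductase (Rattus norvegicus) (on this read-out higher numbers stand for weaker inhibition and lower numbers for stronger inhibition), compound 3 stands second highest of the three numbers, with compound 2 nearest and compound 1 furthest. Compound 4 `COc1ccccc1N1CCN(CCC(Oc2ccc(C(=O)Nc3ccccc3OCCCC(=O)O)cc2)c2ccc(Br)cc2)CC1` differs from compound 3 by bromo in place of methoxy on an aromatic carbon. Within the data shown here, no measured step exchanges methoxy for bromo. Among the measured compounds shown here, the steps that bear on it are a 2.5-fold higher number from compound 2 to compound 3 (0.40 log units; beyond the scatter), a modest change at the same aromatic carbon, and the large steps of a 610-fold lower number from compound 1 to compound 2 (2.79 log units; beyond the scatter) and a 240-fold lower number from compound 1 to compound 3 (2.38 log units; beyond the scatter), which set the whole pendant ring far apart from hydrogen. The bromo compound is therefore expected to land near compound 2 and compound 3, with a 1.9-fold lower number from compound 3 to compound 4 (0.28 log units; within the scatter) as the estimated step. Compound 4 is expected to give about 90 nM, within 35 nM to 250 nM.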

Compound 4, half-maximal inhibitory concentration: 210 nM
Estimate against measurement, compound 4: 2.3-fold (0.37 log units) below; the range from low to high includes it.
By their numbers in this assay, from the lowest: compound 2; then compounds 3 and 4 (each within the scatter of the next); then compound 1.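

In this assay, bromo and methoxy on the pendant ring cannot be told apart, at a 1.2-fold higher number from compound 3 to compound 4 (0.09 log units; within the scatter), while the methyl compound keeps the lower number, at a 3.1-fold higher number from compound 2 to compound 4 (0.50 log units; beyond the scatter). A third group at this aromatic carbon retains a large gain over hydrogen on the chain carbon, at a 200-fold lower number from compound 1 to compound 4 (2.29 log units; beyond the scatter). No measurement shown accounts for these results. On these data alone, what an amine or a carboxylic acid at this aromatic carbon would give remains open, as does an unsubstituted phenyl on the chain carbon.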